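Swapping the chain-end ring on compound 1

A few compounds are considered here, and "the series" means these few. Any claim that something is new, unique, unknown or untested is made for them only; others in the source may bear on it.

Compound 1 `COc1cc2c(Oc3ccc(NC(=O)c4cn(-c5ccccc5)nn4)cc3F)ccnc2cc1OCCCN1CCCCC1` is a two-ring core carrying an amide-linked triazole with a phenyl group on one nitrogen, and a three-carbon chain that ends in a piperidin-1-yl group. In a functional assay on HT-29 cells (Homo sapiens) for cytotoxicity, read by MTT assay, with a stated time of 72 h (on this read-out higher numbers stand for weaker inhibition and lower numbers for stronger inhibition), compound 1 gives 180 nM, the lowest of the two numbers measured here. Compound 2 `COc1cc2c(Oc3ccc(NC(=O)c4cn(-c5c(C)cccc5C)nn4)cc3F)ccnc2cc1OCCCN1CCCCC1` differs only at the triazole, where a 2,6-dimethylphenyl replaces the phenyl; in this assay compound 2 gives 3690 nM, and the step of a 21-fold higher number from compound 1 to compound 2 (1.31 log units; beyond the scatter) is large.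

Compound 3 `COc1cc2c(Oc3ccc(NC(=O)c4cn(-c5ccccc5)nn4)cc3F)ccnc2cc1OCCCN1CCN(C)CC1` is the other kind of change, at the far end of the chain: 4-methylpiperazin-1-yl in place of piperidin-1-yl on a saturated chain carbon, three bonds along the chain from an oxygen on an aromatic ring. For the measured compounds named here, no measured step touches this part of the molecule; the only step known, from compound 1 to compound 2, concerns the triazole substituent and says nothing about the chain end. The expectation is therefore modest: compound 3 is expected to sit close to compound 1, with a step of a 1.2-fold higher number from compound 1 to compound 3 (0.09 log units; within the scatter) that likely stays within the scatter. Compound 3 is estimated at 220 nM, within a range from 80 nM to 600 nM.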

Compound 3, half-maximal inhibitory concentration: 180 nM
Compound 3: the middle estimate sits 1.2-fold (0.09 log units) above what was measured; measured number inside the range.
By their numbers in this assay, from the lowest: compounds 1 and 3 (each within the scatter of the next); then compound 2.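

For the compounds shown here, until this point, the only change with a known effect was on the triazole, and the end of the chain was untested. Placing 4-methylpiperazin-1-yl where piperidin-1-yl stood gives no change at the digits printed from compound 1 to compound 3 (within the scatter) in this assay so this swap at the chain end leaves the read-out unmoved. That stands in clear contrast to the large step at the triazole, a 21-fold higher number from compound 1 to compound 2 (1.31 log units; beyond the scatter) and shows that the two sites of the molecule need not respond alike. Nothing available here explains why the two chain-end rings read the same.

One unchanged result covers a single swap, so it does not show that any group would be accepted at the chain end: a morpholin-4-yl ring, a dimethylamino group, a carboxylic acid or a longer chain carrying the 4-methylpiperazin-1-yl ring could each read differently. Also open, on these data alone, is whether the same swap would read alike with 2,6-dimethylphenyl on the triazole, as in compound 2, and whether the match between compound 1 and compound 3 extends to other cell lines.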